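Morpholin-4-yl for piperidin-1-yl on the sulfonyl sulfur

The compounds below may be only part of what the source reports. "The series", "measured", "known", "first", "only" and "open" are said of these compounds alone.

In an ADME assay on microsomes from liver (Mus musculus) for metabolic stability, tested at 5 uM (a higher number here means that the compound lasts longer, a lower number that the compound disappears faster), compound 1 `O=C(O)c1ccc(NCCCCCCCC(F)(F)F)c(S(=O)(=O)N2CCCC2)c1` gives > 1 h, a limit of the assay and not a number. Compound 2 `O=C(O)c1ccc(NCCCCCCCC(F)(F)F)c(S(=O)(=O)N2CCCCC2)c1` gives > 1 h, also a limit, and so stands at the limit of > 1 h in this assay, at which 2 of the 2 values shown sit. Among the measured compounds shown here, the one measured step, a step that the two limits leave unreadable from compound 1 to compound 2, offers no size to carry forward. Compound 3 `O=C(O)c1ccc(NCCCCCCCC(F)(F)F)c(S(=O)(=O)N2CCOCC2)c1` has morpholin-4-yl in place of piperidin-1-yl on a sulfonyl sulfur. With no readable step as a guide, the expected result in this assay is a step that the limit leaves unreadable from compound 2 to compound 3, no larger than the scatter and with no readable direction. For compound 3 the estimated half-life is 1.5 h, with an expected range from 0.7 h to 3 h.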

Compound 3, half-life: > 1 h
Compound 3: only a limit was reported (the forecaster's own chance of this, stated with the estimate: 75%); the middle value does not contradict the limit.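

No step can be read among compound 1, compound 2 and compound 3 in this assay, since each result is a limit of the assay and not a number: the limit of > 1 h in this assay, at which 3 of the 3 values shown sit.

The compounds shown leave open whether pyrrolidin-1-yl, piperidin-1-yl and morpholin-4-yl on the sulfonyl sulfur differ at all in half-life.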